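The source may report more compounds than this note shows. Statements on the series, on what has been measured and on what is new or still open speak of the compounds shown alone.

Measured compounds:

Compound 1, `COc1cc([C@H]2C[C@]2(CO)C(=O)Nc2ccccc2Cl)cc(OC)c1OC`: in a functional assay on A549 cells (Homo sapiens) for cytotoxicity, read by MTT assay, with a stated time of 48 h (on this read-out lower numbers stand for stronger inhibition and higher numbers for weaker inhibition), compound 1 gives 36700 nM.
Compound 2, `CCOC(=O)[C@]1(C(=O)Nc2ccccc2Cl)C[C@@H]1c1cc(OC)c(OC)c(OC)c1`: compound 2 gives 50900 nM.
Compound 3, `COc1cc([C@H]2C[C@@]2(CO)C(=O)NCc2ccc(C)cc2)cc(OC)c1OC`: compound 3 gives 63800 nM.

Compound 2 stands second highest of the three numbers; its nearest neighbour is compound 3, its furthest compound 1, and both gaps lie within the scatter, so the three measured compounds cannot be ordered against one another on this read-out.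

Compound 4, `CCOC(=O)[C@]1(C(=O)Nc2ccccc2Cl)C[C@H]1c1cc(OC)c(OC)c(OC)c1`, is the next compound to be measured. Its difference from compound 2 is the two compounds have the same atoms and bonds and differ only in configuration as drawn: 1 of 2 stereo elements differ; a stereocentre at a saturated ring carbon is drawn R in compound 2 and S in compound 4. Among the measured compounds shown here, the only measured step that connects two compounds by a single change is a 1.4-fold higher number from compound 1 to compound 2 (0.14 log units; within the scatter); it concerns the group on the saturated ring carbon, not configuration, and is itself within the scatter. For the measured compounds named here, no measured pair isolates a change of configuration at a ring stereocentre. Compounds 1 and 3 are drawn with differing configuration at the quaternary ring carbon, but they also differ in the amide part, so their two values, which lie within the scatter of each other, say nothing clean about configuration.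

Going by the values given here, with no step bearing on the change, the expectation for compound 4 is a step no larger than the scatter, a 1.0-fold lower number from compound 2 to compound 4 (0.01 log units; within the scatter), in either direction. Compound 4 is therefore estimated at 50000 nM, with a range from 18000 nM to 140000 nM.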

Compound 4, half-maximal inhibitory concentration: 13400 nM
The estimate for compound 4 lay 3.7-fold (0.57 log units) above the measured number, and the stated range ends above it.
By their numbers in this assay, from the lowest: compound 4; then compounds 1, 2 and 3 (each within the scatter of the next).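

In this assay, the series now holds its first step beyond the scatter, and it comes from configuration alone (a 3.8-fold lower number from compound 2 to compound 4 (0.58 log units; beyond the scatter)). Among the compounds shown here, the only earlier single change, ethoxycarbonyl in place of hydroxymethyl on a saturated ring carbon, stayed within the scatter (a 1.4-fold higher number from compound 1 to compound 2 (0.14 log units; within the scatter)), so the earlier compounds gave no sign that any one change matters on this read-out. The step can be assigned to the stereocentre at the saturated ring carbon, with the drawn S form giving the lower number, because no other feature separates the pair: the fact that compounds 2 and 4 differ only in the configuration as drawn

Going by these compounds, whether the same inversion at this ring carbon would lower the number for the hydroxymethyl compound 1 or the benzylic amide compound 3 remains open, as does the effect of inverting the other stereocentre of compound 4. Also open, on these data alone, is how the number for compound 4 would respond if a carboxylic acid or a primary amide took the place of its ethoxycarbonyl group.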